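This account rests on a few compounds, and the source may have more. Where it says the series, first, only, none or still open, it means among the compounds named here.

Of the compounds shown here, three sharing one core have been measured in a functional assay on A549 cells (Homo sapiens) for antiproliferative activity, read by sulforhodamine B assay, with a stated time of 48 h (on this read-out lower numbers stand for stronger inhibition and higher numbers for weaker inhibition), so far. Compound 1 (`COc1cc(OC)c2sc(-c3ccc(N/C=C\C(=O)c4ccc(OC)c(O)c4)c(C)c3)nc2c1`) reads 14300 nM and compound 2 (`COc1ccc(C(=O)/C=C\Nc2ccc(-c3nc4cc(OC)c(OC)c(OC)c4s3)cc2C)cc1O`) reads 15400 nM while compound 3 (`COc1ccc(C(=O)/C=C\Nc2ccc(-c3nc4cc(OC)c(OC)c(OC)c4s3)cc2)cc1O`) reads 23000 nM on this scale. Compound 2 lies within the scatter of both others, so it holds no rank among them.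

Compound 4 (`COc1cc(C(=O)/C=C\Nc2ccc(-c3nc4cc(OC)c(OC)c(OC)c4s3)cc2C)cc(OC)c1OC`) differs from compound 2 at one place, with 3,4,5-trimethoxyphenyl in place of 3-hydroxy-4-methoxyphenyl on a carbonyl carbon. Two measured steps are available, and neither touches that group. One is a 1.1-fold higher number from compound 1 to compound 2 (0.03 log units; within the scatter) for methoxy in place of hydrogen on an aromatic carbon, and the other is a 1.5-fold higher number from compound 2 to compound 3 (0.17 log units; within the scatter) for hydrogen in place of methyl on an aromatic carbon. Both stay within the scatter, yet they report on other parts of the molecule and give only indirect guidance. With no direction to draw from them, no shift beyond the scatter is expected in this assay for compound 4, though the range must stay wide since this group has not been varied. The estimated change is a 1.0-fold lower number from compound 2 to compound 4 (0.01 log units; within the scatter) at its middle. For compound 4 the estimate is 15000 nM with an expected range from 5000 nM to 45000 nM overall.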

Compound 4, half-maximal inhibitory concentration: 23300 nM
Compound 4: middle estimate off by 1.6-fold (0.19 log units), on the low side, within the range that was stated.
By their numbers in this assay, from the lowest: compounds 1, 2, 3 and 4 (each within the scatter of the next).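

In this assay, the exchange of 3-hydroxy-4-methoxyphenyl for 3,4,5-trimethoxyphenyl on a carbonyl carbon gives a 1.5-fold higher number from compound 2 to compound 4 (0.18 log units; within the scatter), and this is the only step shown that varies this place. The entering group has 12 heavy atoms against 9 and 0 hydrogen-bond donors against 1, yet in this single pair these differences together leave the result within the scatter. No measurement offered here accounts for the result or bears on how these groups act at this place.

The compounds shown leave open whether the loss of the hydroxy group and the gain of methoxy groups each have little effect or instead offset one another, since the two occur together in this one step. They also leave open whether a group of a different kind on the aromatic ring at this place, such as an amine or a carboxylic acid, would move the number in this assay beyond the scatter, as no step shown so far does.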